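The source may hold more compounds than are shown below. What is called first, only, known or untested is meant among the compounds shown, and "the series" means these compounds.

Measured so far in a functional assay on NCI-H460 cells (Homo sapiens) for cytotoxicity, read by MTT assay; a higher number here means a weaker inhibitor, a lower number a stronger inhibitor:

- compound 1 `Cc1nc(Nc2ccc(Cl)c(Cl)c2)sc1C(=O)/C=C/c1ccccc1` gives 22700 nM
- compound 2 `COc1cccc(/C=C/C(=O)c2sc(Nc3cccc(Cl)c3)nc2C)c1` gives > 25000 nM

For compound 2 this entry is a limit of the assay, not a measured number. Compound 2 sits at the limit of > 25000 nM in this assay, at which 1 of the 2 values shown sits. On the numbers shown, compound 2 therefore stands at the weak end of what this assay can report, and compound 1 is a weak inhibitor as well, so the two values agree on weak cytotoxicity without showing any order between them.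

The next compound, compound 3 `COc1cccc(/C=C/C(=O)c2sc(Nc3ccc(Cl)c(Cl)c3)nc2C)c1`, differs from compound 2 in one place: chloro in place of hydrogen on an aromatic carbon. Compound 1 already carries the same 3,4-dichlorophenyl group on a shared core and is a weak inhibitor, and compound 2 with its 3-chlorophenyl group reaches only a limit. Within the data shown here, no measured step connects these two, so nothing here shows that adding a chloro group changes potency. The step from compound 2 to compound 3 is therefore expected to be none beyond the scatter, a step that the limit leaves unreadable from compound 2 to compound 3.

Compound 3 is estimated at 28000 nM, within a range of 12000 nM to 70000 nM, quite possibly again only as a limit.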

Compound 3, half-maximal inhibitory concentration: 20100 nM
Beside the measured number, compound 3's estimate is 1.4-fold (0.14 log units) above it, within the range that was stated.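

The chloro step now has a measured number on one side: in this assay it reads an at least 1.2-fold lower number from compound 2 to compound 3 (0.09 log units; that floor lies within the scatter), which is a floor and not the true size of the step, so a small effect and a larger one both remain possible. Compound 2 has only a limit of the assay, not a number: the limit of > 25000 nM in this assay, at which 1 of the 3 values shown sits.

The other step has a number at both ends, and with the 3,4-dichlorophenyl group held constant, the added methoxy group gives a 1.1-fold lower number from compound 1 to compound 3 (0.05 log units; within the scatter), so compound 1 and compound 3 cannot be told apart in this assay.

The compounds shown leave open whether any group at the chloro position can move the number beyond the scatter, since both compounds with the 3,4-dichlorophenyl group remain weak inhibitors. A fluoro group, a trifluoromethyl group or an amine in place of this chloro, or a hydroxyl group or a carboxylic acid in place of the methoxy, would show whether either position can shift the value at all.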